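A few compounds are considered here, and "the series" means these few. Any claim that something is new, unique, unknown or untested is made for them only; others in the source may bear on it.

Compound 2 `Nc1ccc2sc(NC(=S)NC(=O)c3ccc([N+](=O)[O-])cc3)nc2c1` was tested in a functional assay on HeLa cells (Homo sapiens) for cytotoxicity, read by MTT assay, with a stated time of 24 h; a lower number here means a stronger inhibitor, a higher number a weaker inhibitor. In this assay compound 2 gives 63100 nM. Its closest relative with a number is compound 1 `Nc1ccc2sc(NC(=S)NC(=O)c3ccccc3)nc2c1`; in this assay compound 1 gives 70100 nM, and the step of a 1.1-fold lower number from compound 1 to compound 2 (0.05 log units; within the scatter) separates the two. Compound 3 `CCCCC(=O)NC(=S)Nc1nc2cc(N)ccc2s1` belongs to the same series, but in this assay compound 3 gives "not determined" (no result reported), so it offers no number to compare with. Among the numbers shown, compound 2 therefore has a single neighbour, compound 1, whose value lies within the scatter of its own, and no further number to compare with.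

Compound 4 `O=C(NC(=S)Nc1nc2cc(Br)ccc2s1)c1ccc([N+](=O)[O-])cc1` differs from compound 2 in one place: bromo in place of amino on an aromatic carbon. Among the compounds with values here, no measured step concerns this exchange. Within the data shown here, the only step in the set, a 1.1-fold lower number from compound 1 to compound 2 (0.05 log units; within the scatter), concerns a different part of the shared core and stayed within the scatter, so it gives no guidance on the size or direction of the present change. With nothing in the data pointing one way, the step of a 1.1-fold lower number from compound 2 to compound 4 (0.02 log units; within the scatter) is expected to remain within the scatter, though with wide uncertainty. Compound 4 is accordingly estimated to give about 60000 nM in this assay, with a range from 20000 nM to 150000 nM.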

Compound 4, half-maximal inhibitory concentration: 56500 nM
Compound 4: the middle estimate sits 1.1-fold (0.03 log units) above what was measured; low and high end bracket the measured number.
By their numbers in this assay, from the lowest: compounds 4, 2 and 1 (each within the scatter of the next).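

Exchanging amino for bromo on an aromatic carbon of the six-membered aromatic ring takes away the hydrogen-bond donor and hydrogen-bond acceptor counted for amino, yet in this assay the step of a 1.1-fold lower number from compound 2 to compound 4 (0.05 log units; within the scatter) stays within the scatter. Within the data shown here, this is the first reading at this position, as the earlier step concerned nitro in place of hydrogen in another part of the compound, and it shows that, with the nitro group present, this assay does not separate amino from bromo here. No accompanying measurement bears on what lies behind this result, so the step stands as an observation only.

With both steps now within the scatter, the compounds shown do not reveal whether any change at either place can move the number beyond it, and it remains open whether a chloro, a methoxy, a carboxylic acid or a longer chain at the position held by amino and bromo would do so. As far as these compounds go, it also remains open whether the same exchange of amino for bromo would give a similar step with hydrogen in place of nitro, as in compound 1.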